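Compound 3 to compound 4: swapping the acyl group

The compounds below may be only part of what the source reports. "The series", "measured", "known", "first", "only" and "open" are said of these compounds alone.

compound 1 `Cc1c2c(n3c1CCNC[C@@H](C)[C@H](C)Nc1cc-3ccc1C(N)=O)CC(C)(C)CC2=O`: 24 nM
compound 2 `Cc1c2c(n3c1CCN(C)C[C@@H](C)[C@H](C)Nc1cc-3ccc1C(N)=O)CC(C)(C)CC2=O`: 27 nM
compound 3 `Cc1c2c(n3c1CCN(C(=O)C1(N)CC1)C[C@@H](C)[C@H](C)Nc1cc-3ccc1C(N)=O)CC(C)(C)CC2=O`: 81 nM

In a functional assay on HCT-116 cells (Homo sapiens) for antiproliferative activity (a higher number here means a weaker inhibitor, a lower number a stronger inhibitor), compound 3 gives 81 nM, the highest number of the three measured compounds. Compound 1 and compound 2 cannot be told apart, with a 1.1-fold higher number from compound 1 to compound 2 (0.05 log units; within the scatter).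

Compound 4 `Cc1c2c(n3c1CCN(C(=O)[C@@H](O)C(C)C)C[C@@H](C)[C@H](C)Nc1cc-3ccc1C(N)=O)CC(C)(C)CC2=O` keeps the core of compound 3 and carries 1-hydroxy-2-methylpropyl in place of 1-aminocyclopropyl on a carbonyl carbon whose other neighbours are: amide-type nitrogen in a ring. The difference counts as 1-hydroxy-2-methylpropyl in place of 1-aminocyclopropyl on a carbonyl carbon.

Among the measured compounds shown here, two measured steps bear on this change, and both introduce the (1-aminocyclopropyl)carbonyl group: a 3.4-fold higher number from compound 1 to compound 3 (0.53 log units; beyond the scatter) and a 3.0-fold higher number from compound 2 to compound 3 (0.48 log units; beyond the scatter). Both are modest, so placing this acyl group on the nitrogen cost little in these compounds. Neither step exchanges one acyl group for another, and the data therefore give no direction for the swap itself. With compound 4 remaining an amide, as compound 3 is at 81 nM, no shift beyond the scatter is expected in this assay. The expected size of the change is a 1.1-fold lower number from compound 3 to compound 4 (0.03 log units; within the scatter).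

Compound 4 is estimated at 75 nM, with an expected range from 30 nM to 190 nM.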

Compound 4, half-maximal inhibitory concentration: 45 nM
Compound 4: middle estimate off by 1.7-fold (0.22 log units), on the high side, and the stated range covers the measured number.
By their numbers in this assay, from the lowest: compounds 1, 2, 4 and 3 (each within the scatter of the next, the first and the last beyond it).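

In this assay, putting 1-hydroxy-2-methylpropyl in place of 1-aminocyclopropyl on the carbonyl carbon gives a 1.8-fold lower number from compound 3 to compound 4 (0.26 log units; within the scatter), so this position accepts an open-chain group with a hydroxyl and a defined stereocentre as readily as the ring-bearing amine, and the two acyl groups cannot be told apart here. The (1-aminocyclopropyl)carbonyl group lay beyond the scatter of the hydrogen and the methyl on the amine nitrogen in a ring, whereas the (1-hydroxy-2-methylpropyl)carbonyl group does not, with a 1.7-fold higher number from compound 2 to compound 4 (0.22 log units; within the scatter) and a 1.9-fold higher number from compound 1 to compound 4 (0.27 log units; within the scatter). No measurement offered here gives any reason for these numbers.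

As far as these compounds go, it remains open how the opposite configuration at the stereocentre of 1-hydroxy-2-methylpropyl would read in this assay, and so whether that centre matters at this position at all. Also open, from the compounds shown here alone, is whether an open-chain 1-amino-2-methylpropyl group, a carboxylic acid or a longer alkyl chain on the same carbonyl carbon would stay within the scatter of compound 1, which would show how much variation this position tolerates.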